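This account rests on a few compounds, and the source may have more. Where it says the series, first, only, none or still open, it means among the compounds named here.

In an ADME assay on BaF3 cells (Mus musculus) for antiproliferative activity, read by CCK-8 assay, with a stated time of 72 h (a lower number here means a stronger inhibitor of growth, a higher number a weaker inhibitor of growth), compound 1 `O=C(CCSc1ccc2c(/C=C/c3ccccn3)n[nH]c2c1)Nc1ccccc1` gives 690 nM as its number. Going by the values given here, compound 2 `O=C(CCSc1ccc2c(/C=C/c3ccccn3)n[nH]c2c1)Nc1cccc(Cl)c1` gives 9350 nM as the higher of the two numbers so far, which makes it the weaker inhibitor of growth of the pair. Among the compounds with values here, the only measured step is a 14-fold higher number from compound 1 to compound 2 (1.13 log units; beyond the scatter) and it is large, beyond the scatter, with chloro in place of hydrogen on an aromatic carbon. Compound 3 `O=C(CCSc1ccc2c(/C=C/c3ccccn3)n[nH]c2c1)Nc1cccc(C(F)(F)F)c1` differs from compound 2 in one group, with trifluoromethyl in place of chloro on an aromatic carbon, meta to a large group, as counted here: trifluoromethyl in place of chloro on an aromatic carbon and nothing else in the structure changes. Within the data shown here, no measured step exchanges these two groups. Among the measured compounds shown here, the step of a 14-fold higher number from compound 1 to compound 2 (1.13 log units; beyond the scatter) shows only that a group at this place can matter greatly when it replaces hydrogen, and here a group replaces another group. In this assay no step beyond the scatter is therefore expected, and no direction is favoured with confidence. The expected change is a 1.2-fold lower number from compound 2 to compound 3 (0.07 log units; within the scatter) and so remains modest. Compound 3 is estimated at 8000 nM with an expected range from 2500 nM to 20000 nM for repeated measurements.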

Compound 3, concentration for 50% growth inhibition: 2300 nM
Estimate against measurement, compound 3: 3.5-fold (0.54 log units) above; measured number below the stated range.
By their numbers in this assay, from the lowest: compound 1; then compound 3; then compound 2.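

In this assay, the effect at this place depends on which group sits there and not only on hydrogen being replaced: trifluoromethyl in place of chloro gives a 4.1-fold lower number from compound 2 to compound 3 (0.61 log units; beyond the scatter), so two groups on the same aromatic carbon can give clearly different numbers. Trifluoromethyl still does not match hydrogen, since the change at this carbon gives a 3.3-fold higher number from compound 1 to compound 3 (0.52 log units; beyond the scatter), and compound 1 therefore keeps the lowest number of the three, with hydrogen ahead of both groups tried here. Nothing measured alongside these numbers accounts for the gap between chloro and trifluoromethyl.

The compounds shown leave open how a methoxy group, an amine or a carboxylic acid would fare on this same carbon, and whether any group there could bring the number below that of compound 1 rather than only above it. They also leave open whether chloro and trifluoromethyl would keep this same order on another carbon of the ring, since each sits at only one place here.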